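Compound 2 to Compound 4: One Ring Group Exchanged

The source may report more compounds than this note shows. Statements on the series, on what has been measured and on what is new or still open speak of the compounds shown alone.

In a functional assay for inhibition, with Homo sapiens as the target (a lower number here means a stronger inhibitor, a higher number a weaker inhibitor), compound 2 `CC(C)(C)Sc1c(CC(C)(C)C(=O)O)n(Cc2ccc(Cl)cc2)c2ccc(OCc3ccc4cc(F)c(F)cc4n3)cc12` gives 7 nM, the lower of the two actual numbers available for this series. Compound 3 `CC(C)(C)Sc1c(CC(C)(C)C(=O)O)n(Cc2ccc(Cl)cc2)c2ccc(OCc3nc4cc(C(F)(F)F)ccc4s3)cc12` gives 22 nM, and the gap between these two values lies beyond the usual scatter. Compound 1 `CCCC(Oc1ccc2c(c1)c(SC(C)(C)C)c(CC(C)(C)C(=O)O)n2Cc1ccc(Cl)cc1)c1ccc2ccccc2n1` is reported only as a limit, > 52 nM, and not as a number.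

The next compound to be tested in this assay is compound 4 `COc1ccc2nc(COc3ccc4c(c3)c(SC(C)(C)C)c(CC(C)(C)C(=O)O)n4Cc3ccc(Cl)cc3)sc2c1`, which has not yet been measured. The change from compound 2 is a single exchange on a saturated chain carbon bound to an oxygen on an aromatic ring: a group of 11 heavy atoms (8 carbon, 1 nitrogen, 1 oxygen, 1 sulfur; one five-membered aromatic ring with 2 hetero atoms, one six-membered aromatic ring of carbon only) in place of a group of 12 heavy atoms (9 carbon, 1 nitrogen, 2 fluorine; one six-membered aromatic ring of carbon only, one six-membered aromatic ring with 1 hetero atom), on a saturated chain carbon bound to an oxygen on an aromatic ring. The group that enters is 6-methoxy-1,3-benzothiazol-2-yl.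

The closest guide is compound 3, which also carries a five-membered aromatic ring with 2 hetero atoms at that place and gives 22 nM. For the measured compounds named here, no measured step isolates this exchange, so the expectation is loose. A moderate rise in the number, towards weaker inhibition and near the edge of the scatter, is expected for the step of a 2.3-fold higher number from compound 2 to compound 4 (0.36 log units; beyond the scatter). For compound 4 the estimated value is 16 nM, with an expected range of 5 nM to 50 nM.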

Compound 4, half-maximal inhibitory concentration: 8 nM
The estimate for compound 4 lay 2.0-fold (0.30 log units) above the measured number; the range from low to high includes it.
By their numbers in this assay, from the lowest: compounds 2 and 4 (each within the scatter of the next); then compound 3. At a limit, above all of these: compound 1.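

The exchange on the saturated chain carbon bound to an oxygen on an aromatic ring leaves the number effectively unchanged in this assay, with a 1.1-fold higher number from compound 2 to compound 4 (0.06 log units; within the scatter). For the compounds shown here, the earlier compounds gave only one group with a five-membered aromatic ring at this place, and in compound 3 that group gave 22 nM, so they could not show that such a group can match the two-fluorine group that leaves. With 6-methoxy-1,3-benzothiazol-2-yl in compound 4, which gives 8 nM, this place accepts two quite different ring groups without a change beyond the scatter, while the difference between the printed values of compound 3 and compound 4 suggests that the substituent on the benzothiazole ring system may matter as well.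

The compounds shown do not tell whether an amine or a carboxylic acid in place of the methoxy group of compound 4 would keep this level of inhibition. They also offer no measurement that explains why the two ring groups give such similar numbers.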